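The source may hold more compounds than are shown below. What is called first, only, known or untested is meant among the compounds shown, and "the series" means these compounds.

Compound 1 `COc1cc(-n2cnc3ccc(-c4ccccc4)cc32)cc(OC)c1OC` gives 2290 nM in a functional assay on MCF7 cells (Homo sapiens) for antiproliferative activity, read by MTT assay, with a stated time of 72 h; a lower number here means a stronger inhibitor, a higher number a weaker inhibitor.
Compound 2 `COc1cc(-n2cnc3ccc(-c4ccc(O)cc4)cc32)cc(OC)c1OC` gives 4160 nM in this assay.
Compound 3 `COc1cc(-n2cnc3ccc(-c4ccc(F)cc4)cc32)cc(OC)c1OC` gives 1770 nM in this assay.

Compound 3 holds the lowest of the three numbers, but only its distance from compound 2 counts: the step of a 2.4-fold lower number from compound 2 to compound 3 (0.37 log units; beyond the scatter) is beyond the scatter and modest, whereas the step of a 1.3-fold lower number from compound 1 to compound 3 (0.11 log units; within the scatter) stays within the scatter, so compound 1 and compound 3 cannot be told apart on these numbers.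

Compound 4 `COc1cc(-n2cnc3ccc(-c4cccc(Cl)c4)cc32)cc(OC)c1OC` differs from compound 3 in one place: 3-chlorophenyl in place of 4-fluorophenyl on an aromatic carbon. Among the measured steps, a 1.3-fold lower number from compound 1 to compound 3 (0.11 log units; within the scatter) shows what a fluoro for a hydrogen on the pendant ring did, and a 1.8-fold higher number from compound 1 to compound 2 (0.26 log units; within the scatter) what a hydroxy did; both stayed within the scatter, and only the swap of hydroxy for fluoro, a 2.4-fold lower number from compound 2 to compound 3 (0.37 log units; beyond the scatter), moved the number beyond it. Among the compounds with values here, no measured step exchanges one halogen for another, and none changes where the substituent sits on the pendant ring, so the data give no direct guide for compound 4. The three compounds together span a narrow band, and the step to compound 4 is therefore expected to stay within the scatter, at a 1.1-fold higher number from compound 3 to compound 4 (0.05 log units; within the scatter). Compound 4 is thus estimated at 2000 nM in this assay, with a range from 900 nM to 4500 nM.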

Compound 4, half-maximal inhibitory concentration: 3120 nM
Compound 4: the middle estimate sits 1.6-fold (0.19 log units) below what was measured; measured number inside the range.
By their numbers in this assay, from the lowest: compounds 3, 1, 4 and 2 (each within the scatter of the next, the first and the last beyond it).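

In this assay, the 3-chlorophenyl group of compound 4 cannot be told apart from any of the three earlier pendant rings, with a 1.4-fold higher number from compound 1 to compound 4 (0.13 log units; within the scatter), a 1.8-fold higher number from compound 3 to compound 4 (0.25 log units; within the scatter) and a 1.3-fold lower number from compound 2 to compound 4 (0.12 log units; within the scatter). This adds a substituent of a new kind, in a new place on the pendant ring, and all three steps stay within the scatter, even though compound 2 and compound 3 stand apart beyond it; on these four compounds, then, compound 4 sits in the gap between them and is separated from neither. The step from the 4-fluorophenyl group changes the halogen and its place on the ring together, so it cannot be assigned to either change, and no measurement at hand accounts for these small differences.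

The compounds shown leave open whether the halogen or its place on the pendant ring matters more in this assay. They also leave open whether an amine, a carboxylic acid or a longer chain such as butyl on that ring would move the number beyond the scatter.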